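The compounds below may be only part of what the source reports. "The series", "measured", "known", "first", "only" and "open" are said of these compounds alone.

Compound 1 `COc1cc2ncnc(Nc3ccc(NC(=O)c4cccc(C)c4)cc3)c2cc1OC` is the starting point of this account. In a functional assay on HepG2 cells (Homo sapiens) for inhibition, read by MTT assay (on this read-out higher numbers stand for weaker inhibition and lower numbers for stronger inhibition), compound 1 gives 7500 nM, the lowest of the two numbers shown, with compound 3 `COc1cc2ncnc(Nc3ccc(NC(=O)c4cccc(F)c4)cc3)c2cc1OC` as its nearest neighbour at 8200 nM in this assay. Compound 2 `COc1cc2ncnc(Nc3ccc(NC(=O)c4ccc(C(C)(C)C)cc4)cc3)c2cc1OC` gives > 100000 nM in this assay, which is a limit of the assay and not a number, namely (the limit of > 100000 nM in this assay, at which 1 of the 3 values shown sits). The step of an at least 13-fold higher number from compound 1 to compound 2 (1.12 log units; beyond the scatter) is large, whereas a 1.1-fold higher number from compound 1 to compound 3 (0.04 log units; within the scatter) stays within the scatter.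

Compound 4 `COc1cc2ncnc(Nc3ccc(NC(=O)c4cccc(Cl)c4)cc3)c2cc1OC` differs from compound 1 by chloro in place of methyl on an aromatic carbon. Within the data shown here, the measured step that bears most directly on this change is the one between compound 1 and compound 3, where fluoro in place of methyl on an aromatic carbon left the number essentially where it was. The large step between compound 1 and compound 2 concerns a different group at a different place on the ring and carries less weight for the present change. The change that leads to compound 4 is therefore expected to give no step beyond the scatter, no change at the digits printed from compound 1 to compound 4 (within the scatter). Compound 4 is thus estimated at 7500 nM in this assay, with an expected range from 3500 nM to 16000 nM.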

Compound 4, half-maximal inhibitory concentration: 12000 nM
Estimate against measurement, compound 4: 1.6-fold (0.20 log units) below; measured number inside the range.
By their numbers in this assay, from the lowest: compounds 1, 3 and 4 (each within the scatter of the next). At a limit, above all of these: compound 2.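

Chloro is a second halogen at this aromatic carbon, and in this assay it too gives no step beyond the scatter, as a 1.6-fold higher number from compound 1 to compound 4 (0.20 log units; within the scatter) and a 1.5-fold higher number from compound 3 to compound 4 (0.17 log units; within the scatter) show, so methyl, fluoro and chloro cannot be told apart here. The earlier compounds shown here showed this flat reading for fluoro alone; compounds 1, 3 and 4 now extend it to three groups on this carbon, which still makes a narrow set. The contrast with the 4-(tert-butyl)phenyl amide also holds for the new compound, with an at least 8.3-fold lower number from compound 2 to compound 4 (0.92 log units; beyond the scatter), although that step changes both the group and its place on the ring, and compound 2 has a limit of the assay and not a number: the limit of > 100000 nM in this assay, at which 1 of the 4 values shown sits.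

Going by these compounds, whether this flat reading would hold for an amine, a carboxylic acid or a methoxy group on the same carbon stays open. Also open, on these data alone, is whether the loss seen with compound 2 goes with the tert-butyl group itself or with its place on the ring, a question that 3-(tert-butyl)phenyl and 4-methylphenyl amides on the same core would separate.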